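The compounds below may be only part of what the source reports. "The series", "measured", "known", "first", "only" and "open" are said of these compounds alone.

Measured so far:
Compound 1 `O=C(O)/C=C/c1cc(O)c(O)c(O)c1` — in a functional assay on C2BBe1 cells (Homo sapiens) for cytotoxicity, read by sulforhodamine B assay, with a stated time of 72 h (on this read-out lower numbers stand for stronger inhibition and higher numbers for weaker inhibition), compound 1 gives 58900 nM
Compound 2 `CCCCCCNC(=O)/C=C/c1ccc(O)c(O)c1` — in this assay compound 2 gives 23400 nM

Of the two numbers, compound 2 has the lower one, and its gap to compound 1 lies beyond the usual scatter of this assay. The two compounds differ in more than one place, so no single change can be read from that gap.

Compound 3 `CCCCCCNC(=O)/C=C/c1cc(O)c(O)c(O)c1` is not yet measured. It comes from compound 2 by one change: hydroxy in place of hydrogen on an aromatic carbon. Among the measured compounds shown here, no measured pair shows this exact change on this scaffold, so its effect is open. Since the added group is small, the step is expected to stay modest, with a slight lean toward a lower number: the expected step is a 1.6-fold lower number from compound 2 to compound 3 (0.19 log units; within the scatter). For compound 3 the expected value in this assay is 15000 nM, in a range from 5000 nM to 45000 nM.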

Compound 3, half-maximal inhibitory concentration: 99800 nM
For compound 3 the middle estimate is 6.7-fold (0.82 log units) below the measured one; measured number outside the range, above it.
By their numbers in this assay, from the lowest: compound 2; then compounds 1 and 3 (each within the scatter of the next).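

In this assay, among the compounds shown here, the step of a 4.3-fold higher number from compound 2 to compound 3 (0.63 log units; beyond the scatter) is the first single change that can be read in this set, and it runs toward weaker inhibition. Hydroxy in place of hydrogen at this spot, on an aromatic carbon ortho to a hydroxy group and meta to a large group, therefore matters: adding just one heavy atom here moves the number beyond the usual scatter. Nothing measured here says why this one added group has that effect.

The compounds shown include only hydrogen and hydroxy at this position, so it remains open whether a methoxy group or a fluorine atom in the same place would give a similar step. On these data alone, it also remains open whether the same step would appear with a longer chain on the amide.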